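The compounds below may be only part of what the source reports. "The series", "measured", "known", "first", "only" and "open" are said of these compounds alone.

Compound 1 `Cc1cccc2sc(NC(=O)CCN3CCN(CCCN(C)C)CC3)nc12` sets the only numerical reference in this set: in an assay on HEK293 cells for antagonist activity at P2X purinoceptor 7 (Homo sapiens), read by fluorescence, with stated times of 30 min and 120 min (a higher number here means a weaker inhibitor, a lower number a stronger inhibitor), compound 1 gives 18100 nM. Compound 2 `Cc1cccc2sc(NC(=O)CCN3CCN(CC4CCCO4)CC3)nc12` shares that core, but in this assay compound 2 gives no result reported, so it stands nowhere on the numbers at hand. Compound 3 `Cc1cccc2sc(NC(=O)CCN3CCN(c4ncccn4)CC3)nc12` differs from compound 2 by pyrimidin-2-yl in place of (oxolan-2-yl)methyl on an amine nitrogen in a ring. For the measured compounds named here, with no measured step between compounds to lean on, no direction is expected beyond the scatter of this assay; the weak value of compound 1 at 18100 nM is the nearest anchor. Compound 3 is expected to give about 15000 nM, within 4000 nM to 60000 nM.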

Compound 3, half-maximal inhibitory concentration: 1330 nM
Compound 3: the middle estimate sits 11-fold (1.05 log units) above what was measured; the measured number lies below the stated range.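

In this assay the group on this amine nitrogen in a ring proves able to move the result well beyond the scatter: pyrimidin-2-yl in place of 3-(dimethylamino)propyl gives a 14-fold lower number from compound 1 to compound 3 (1.13 log units; beyond the scatter) on an otherwise unchanged core. The step from compound 2 to compound 3 cannot be read, so (oxolan-2-yl)methyl remains unplaced. No supporting evidence accounts for this step.

The compounds shown leave open whether a phenyl or pyridin-2-yl group on that nitrogen would give a similar result. They also leave open how a shorter dimethylaminoethyl chain would compare.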